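The source may hold more compounds than are shown below. What is called first, only, known or untested is meant among the compounds shown, and "the series" means these compounds.

Compound 1 `O=C(Nc1cccc(-c2oc3cc(-c4ccc(F)cc4)ccc3c(=O)c2O)c1)c1ccc(F)cc1F` and compound 2 `O=C(Nc1cccc(-c2oc3cc(-c4ccc(F)cc4)ccc3c(=O)c2O)c1)c1ccc(C(F)(F)F)cc1` share one core and differ only in the aryl group attached to the amide carbonyl. In a functional assay on MDA-MB-231 cells (Homo sapiens) for antiproliferative activity, read by CCK-8 assay, with a stated time of 72 h (on this read-out lower numbers stand for stronger inhibition and higher numbers for weaker inhibition), compound 1 gives 11200 nM, while compound 2 gives 29400 nM. For the measured compounds named here, the single measured step, a 2.6-fold higher number from compound 1 to compound 2 (0.42 log units; beyond the scatter), shows how much that one group can move the number. Compound 2 therefore stands at the highest of the two numbers shown, with compound 1 as its only neighbour.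

Compound 3 `Cc1cccc(C(=O)Nc2cccc(-c3oc4cc(-c5ccc(F)cc5)ccc4c(=O)c3O)c2)c1` is the next variation on the same amide carbonyl. Compared with compound 2 the change is 3-methylphenyl in place of 4-(trifluoromethyl)phenyl on a carbonyl carbon.

Going by the values given here, only one step bears on this change, the step from compound 1 to compound 2, and it was modest. Among the compounds with values here, no measured compound carries a 3-methylphenyl group, so its effect is not known from the data. Compound 3 is expected to land somewhere between the two numbers seen so far, with the step of a 1.6-fold lower number from compound 2 to compound 3 (0.21 log units; within the scatter) anticipated. The estimate for compound 3 in this assay is 18000 nM, within a range from 6000 nM to 50000 nM.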

Compound 3, half-maximal inhibitory concentration: 2840 nM
The estimate for compound 3 lay 6.3-fold (0.80 log units) above the measured number; the whole stated range lies above it.
By their numbers in this assay, from the lowest: compound 3; then compound 1; then compound 2.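

In this assay, for the compounds shown here, the aryl group on the amide carbonyl can move the number much further than the first pair of compounds suggested: 3-methylphenyl in place of 4-(trifluoromethyl)phenyl gives a 10-fold lower number from compound 2 to compound 3 (1.02 log units; beyond the scatter), and 3-methylphenyl in place of 2,4-difluorophenyl gives a 3.9-fold lower number from compound 1 to compound 3 (0.60 log units; beyond the scatter). Compound 3 has the lowest number of the three, and its aryl group is the only one of the three made up of carbon alone, although three compounds are too few to make that a rule. No measurement shown here accounts for the difference.

The swap from compound 2 to compound 3 changes both the group on the aromatic ring and the number of its ring position, so the data cannot say which of the two carries the step; 3-(trifluoromethyl)phenyl and 4-methylphenyl would separate them. Also open, going by these compounds, is how the number would respond to an unsubstituted phenyl, or to a longer chain in 3-ethylphenyl, and so whether the methyl group itself is needed at all.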